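Branched alkyl at the imidazole carbon of the xanthine series

The source may report more compounds than this note shows. Statements on the series, on what has been measured and on what is new or still open speak of the compounds shown alone.

Three compounds of the shared core have numbers in an assay on cell membranes for binding affinity to adenosine receptor A1 (Cavia porcellus); on this read-out higher numbers stand for weaker inhibition and lower numbers for stronger inhibition. Compound 2 `CCCn1c(=O)c2nc(C(CC)CC)[nH]c2n(CCC)c1=O` gives 19 nM, the lowest of the three. Compound 1 `CCCn1c(=O)c2nc(C(C)Cc3ccc(OC)cc3)[nH]c2n(CCC)c1=O`, which carries an arylalkyl branch at the same place, gives 220 nM. Compound 3 `CCCn1c(=O)c2nc(C(CC)Oc3ccccc3)[nH]c2n(CCC)c1=O` gives 900 nM; the step of a 47-fold higher number from compound 2 to compound 3 (1.68 log units; beyond the scatter) shows that an oxygen-linked aryl group in place of ethyl on the branch carbon costs heavily in this assay.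

Compound 4 `CCCn1c(=O)c2nc(C(C3CC3)C3CC3)[nH]c2n(CCC)c1=O` differs from compound 2 only by dicyclopropylmethyl in place of pentan-3-yl on an aromatic carbon. Neither measured step bears directly on this change: both introduce an aromatic ring, whereas compound 4 keeps a hydrocarbon branch of two equal arms, as in compound 2, only with small rings in place of ethyl chains. For the measured compounds named here, no step in the set shows what such a ring-for-chain exchange does. The expectation for compound 4 is therefore a number close to that of compound 2, with the step of a 1.1-fold lower number from compound 2 to compound 4 (0.02 log units; within the scatter) expected to remain within the scatter. Compound 4 is estimated at 18 nM in this assay, in the range 5 nM to 65 nM.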

Compound 4, inhibition constant: 3 nM
Beside the measured number, compound 4's estimate is 6.0-fold (0.78 log units) above it; the measured number lies below the stated range.
By their numbers in this assay, from the lowest: compound 4; then compound 2; then compound 1; then compound 3.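

In this assay, dicyclopropylmethyl in place of pentan-3-yl gives a 6.3-fold lower number from compound 2 to compound 4 (0.80 log units; beyond the scatter) and so shows that the number at this aromatic carbon can still fall from that of compound 2. For the compounds shown here, the only earlier step at this place, a 47-fold higher number from compound 2 to compound 3 (1.68 log units; beyond the scatter), ran towards a higher number, so the branch is now seen to respond in both directions, and a hydrocarbon branch with two equal arms need not stop at two ethyl chains. No measurement in hand gives a reason for the lower number with the two three-membered rings.

The compounds shown do not separate the effect of one ring from that of two, which a branch with one cyclopropyl and one ethyl arm would address. As far as these compounds go, whether larger rings, as in dicyclobutylmethyl, or longer chains, as in heptan-4-yl, continue this trend also remains open.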